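Amide series: cytotoxicity outlook for compound 4

This account rests on a few compounds, and the source may have more. Where it says the series, first, only, none or still open, it means among the compounds named here.

Compound 3 `CCOC(=O)CCCCCOc1cccc(CN(C(=O)c2ccc(-c3cnc(OC)nc3OC)cc2)C(C)C)c1` was tested in an ADME assay on Raji cells (Homo sapiens) for cytotoxicity, read by CellTiter-Glo and resazurin assay, with a stated time of 72 h; a higher number here means that more compound is needed for the effect, a lower number that less compound is needed. In this assay compound 3 gives only a limit, > 26000 nM. Compound 1 `CCOC(=O)CCCCCOc1cccc(CN(C(=O)c2ccccc2)C(C)C)c1` gives a limit as well in this assay, > 26000 nM. Compound 2 `CCOC(=O)CCCCCOc1cccc(CN(C(=O)c2ccc(-c3ccncc3)cc2)C(C)C)c1` in this assay likewise gives a limit, > 26000 nM. All three values sit at the limit of > 26000 nM in this assay, at which 3 of the 3 values shown sit, so none of the steps among them can be read: a step that the two limits leave unreadable from compound 1 to compound 2, a step that the two limits leave unreadable from compound 1 to compound 3, a step that the two limits leave unreadable from compound 2 to compound 3. Compound 3 therefore stands at the same limit as the other two, with no number of its own.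

Compound 4 `CCOC(=O)CCCCCOc1cccc(CN(C(=O)c2ccc(-c3cccc(OCC(C)C)c3)cc2)C(C)C)c1` differs from compound 3 in one place: 3-(isobutoxy)phenyl in place of 2,4-dimethoxypyrimidin-5-yl on an aromatic carbon. Going by the values given here, the measured steps that bear on this exchange are the three unreadable ones above, and they leave the size of any effect of swapping this group unknown, since every compound so far sits at the limit. No step beyond the scatter is expected in this assay in either direction. The expected step is a step that the limit leaves unreadable from compound 3 to compound 4. For compound 4 the value in this assay is estimated at 30000 nM, in the range 10000 nM to 100000 nM. A further limit rather than a number is the most likely outcome for compound 4.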

Compound 4, half-maximal effective concentration: > 26000 nM
Compound 4 was reported as a limit (the forecaster's own chance of this, stated with the estimate: 70%); the middle value does not contradict the limit.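

In this assay, going by these compounds alone, compound 4 gives only a limit, and no step from compound 1, compound 2 or compound 3 to compound 4 can be read, as all four compounds share one limit: the limit of > 26000 nM in this assay, at which 4 of the 4 values shown sit. The compounds shown leave open whether any group at this aromatic carbon gives a measurable half-maximal effective concentration.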